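Swapping the amide aryl group on an acetamido-quinoline scaffold

The source may report more compounds than this note shows. Statements on the series, on what has been measured and on what is new or still open speak of the compounds shown alone.

Measured compounds:
compound 1 `Nc1cccc2c(-c3cccc(NC(=O)c4ccc(Cl)c(C(F)(F)F)c4)c3)ccnc12`: 2900 nM
compound 2 `Nc1cccc2c(-c3cccc(NC(=O)c4nccs4)c3)ccnc12`: 15800 nM
compound 3 `COc1ccc(C(=O)Nc2cccc(-c3ccnc4c(NC(C)=O)cccc34)c2)cc1OC`: 2700 nM

In a functional assay on SK-MEL-28 cells (Homo sapiens) for antiproliferative activity, read by sulforhodamine B assay, with a stated time of 48 h (on this read-out higher numbers stand for weaker inhibition and lower numbers for stronger inhibition), compound 3 gives the lowest of the three numbers, yet compound 1 sits within the scatter of it, while compound 2 lies well beyond the scatter with a weaker value. Compound 4 `CC(=O)Nc1cccc2c(-c3cccc(NC(=O)c4ccc(Cl)c(C(F)(F)F)c4)c3)ccnc12` is not yet measured. It differs from compound 3 by 4-chloro-3-(trifluoromethyl)phenyl in place of 3,4-dimethoxyphenyl on a carbonyl carbon. Compound 1 already carries this entering group, and in this assay compound 1 gives 2900 nM, which stands within the scatter of compound 3. No change beyond the scatter is therefore expected, and the step from compound 3 to compound 4 is estimated as a 1.0-fold lower number from compound 3 to compound 4 (0.02 log units; within the scatter). Compound 4 is expected to give about 2600 nM, in the range 900 nM to 7500 nM.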

Compound 4, half-maximal inhibitory concentration: 3500 nM
For compound 4 the middle estimate is 1.3-fold (0.13 log units) below the measured one; measured number inside the range.
By their numbers in this assay, from the lowest: compounds 3, 1 and 4 (each within the scatter of the next); then compound 2.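

In this assay, 4-chloro-3-(trifluoromethyl)phenyl in place of 3,4-dimethoxyphenyl on a carbonyl carbon gives a 1.3-fold higher number from compound 3 to compound 4 (0.11 log units; within the scatter), so this assay does not separate these two groups when the acetyl is present. Acetyl in place of hydrogen on a nitrogen on an aromatic ring gives a 1.2-fold higher number from compound 1 to compound 4 (0.08 log units; within the scatter), so this change also stays within the scatter with the 4-chloro-3-(trifluoromethyl)phenyl group in place. Nothing available explains either step. Still open, as far as these compounds go, is whether acetyl would behave alike alongside the amide group of compound 2, and whether a longer acyl chain or a methanesulfonyl group on that nitrogen would change the number.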